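Swapping a Chlorophenyl Acyl Group for an Octanoyl Chain

The compounds below may be only part of what the source reports. "The series", "measured", "known", "first", "only" and "open" are said of these compounds alone.

Going by the values given here, compound 1 `O=C(Nc1ccccc1O)C1CCc2ccccc2N1C(=O)c1ccccc1Cl` is the only compound with a full number in a functional assay on PC-3 cells (Homo sapiens) for cytotoxicity, read by sulforhodamine B assay, with a stated time of 72 h; on this read-out higher numbers stand for weaker inhibition of growth and lower numbers for stronger inhibition of growth: in this assay compound 1 gives 60000 nM. Compound 2 `CCC(=O)N1c2ccccc2CCC1C(=O)Nc1ccccc1C(F)(F)F` gives only a limit in this assay, > 80000 nM, which is not a number; it sits at the limit of > 80000 nM in this assay, at which 1 of the 2 values shown sits. Compound 3 `CCCCCCCCC(=O)N1c2ccccc2CCC1C(=O)Nc1ccccc1O` differs from compound 1 by octyl in place of 2-chlorophenyl on a carbonyl carbon. Among the compounds with values here, no measured pair covers this change, so compound 3 is expected to stay within the scatter of compound 1, with a step of no change at the digits printed from compound 1 to compound 3 (within the scatter) that is estimated to be none beyond the scatter. Compound 3 is expected to give 60000 nM in this assay, within 20000 nM to 150000 nM.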

Compound 3, concentration for 50% growth inhibition: 45200 nM
Estimate against measurement, compound 3: 1.3-fold (0.12 log units) above, within the range that was stated.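

In this assay, putting octyl in place of 2-chlorophenyl on a carbonyl carbon gives a 1.3-fold lower number from compound 1 to compound 3 (0.12 log units; within the scatter). An aromatic ring is therefore not required at this place to hold the reading of compound 1, and a chain without any ring serves equally well here. Nothing shown bears on why the two groups read alike.

On these data alone, it remains open whether a longer chain, or an octyl chain ending in an amine or a carboxylic acid, would move the reading beyond the scatter.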